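The source may hold more compounds than are shown below. What is called first, only, known or untested is meant among the compounds shown, and "the series" means these compounds.

The study measured three compounds in a functional assay on PC-3 cells (Homo sapiens) for antiproliferative activity, read by MTT assay, tested at 1 uM; on this read-out higher numbers stand for a stronger effect at the one concentration tested and lower numbers for a weaker effect. Compound 1 `COc1ccc(/C=N/NC(=O)c2cc(OC)c(OC)c(OC)c2)c(OC)c1` gave 10%, compound 2 `COc1cc(C2=NN(C(C)=O)C(c3c(Cl)cccc3Cl)O2)cc(OC)c1OC` gave 5.1%, and compound 3 `COc1cc(C(=O)N/N=C/c2cccc(F)c2)cc(OC)c1OC` gave 53.5%. Compound 2 holds the lowest of the three numbers; its gap to compound 1 lies within the scatter, whereas compound 3 stands beyond it. Compound 4 `COc1ccc(C2OC(c3cc(OC)c(OC)c(OC)c3)=NN2C(C)=O)c(OC)c1` has not yet been measured. It differs from compound 2 in one place: 2,4-dimethoxyphenyl in place of 2,6-dichlorophenyl on a saturated ring carbon. For the measured compounds named here, no measured pair covers this exchange, but compound 1 also carries a 2,4-dimethoxyphenyl on its own core and gives 10% in this assay. The expected step is therefore a number 4.9 percentage points higher from compound 2 to compound 4 (within the scatter), none beyond the scatter. Compound 4 is estimated at 10%, within a range from 0% to 28%.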

Compound 4, a percentage reported as inhibition, at one concentration (the size of the read-out at that concentration, not a potency): 69.5%
Beside the measured number, compound 4's estimate is 59.5 percentage points below it; measured number outside the range, above it.
By their numbers in this assay, from the lowest: compounds 2 and 1 (each within the scatter of the next); then compound 3; then compound 4.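

For the compounds shown here, on the shared core of compounds 2 and 4, the group on the saturated ring carbon proves decisive in this assay: exchanging 2,6-dichlorophenyl for 2,4-dimethoxyphenyl gives a number 64.4 percentage points higher from compound 2 to compound 4 (beyond the scatter) as the only change. The low number of compound 2 is therefore not fixed by the core and its acetyl group alone. Nothing available explains this step.

Going by these compounds, both chlorines and both methoxy groups change together, so the contribution of each remains open. Also open, on these data alone, is where an unsubstituted phenyl on this carbon would fall relative to compound 2 and compound 4.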